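A few compounds are considered here, and "the series" means these few. Any claim that something is new, unique, unknown or untested is made for them only; others in the source may bear on it.

Measured compounds in a physicochemical assay for lipophilicity, at pH 7.4; a higher number here means a more lipophilic compound, a lower number a more polar compound:

- compound 1 `COC(c1cc(Cl)c2c(c1Cl)C(=O)N(Cc1c(C)cc(C)[nH]c1=O)CC2)C1CCN(C2COC2)CC1` — 2.7; 2.8 (2 entries)
- compound 2 `Cc1cc(C)c(CN2CCc3c(Cl)cc([C@@H](C)CO)c(Cl)c3C2=O)c(=O)[nH]1` — 2.5
- compound 3 `COc1cc(C)[nH]c(=O)c1CN1CCc2c(Cl)cc([C@@H](O)C3COC3)c(Cl)c2C1=O` — 1.3

Compound 1 is entered twice, (the several entries of compound 1 in this assay, 2.7; 2.8 (2 entries)), and the two entries lie within the scatter of each other, so compound 1 has no single number to rank. Of the two compounds with a single number, compound 3 gives the lower one; the nearest, compound 2, stands higher by a gap beyond the scatter. Within the data shown here, compound 3 therefore sits at the polar end of what has been measured in this assay so far.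

Compound 4 `COc1cc(C)[nH]c(=O)c1CN1CCc2c(Cl)cc([C@H](O)C3COC3)c(Cl)c2C1=O` has not yet been measured in this assay. It differs from compound 3 as follows: the two compounds have the same atoms and bonds and differ only in configuration as drawn: 1 of 1 stereo elements differ; a stereocentre at a saturated chain carbon is drawn S in compound 3 and R in compound 4. Among the measured compounds shown here, no step between measured compounds with this kind of difference is recorded, so there is no measured precedent to lean on. Nothing in the change adds or removes any atom or bond, and the expectation is a step of no size beyond the scatter in either direction, estimated as no change at the digits printed from compound 3 to compound 4 (within the scatter). Compound 4 is accordingly expected to give 1.3 in this assay, with the range 1 to 1.6 covering the usual spread of repeated measurements around the value of compound 3.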

Compound 4, distribution coefficient: 1.4
The estimate for compound 4 lay 0.10 log units below the measured number; measured number inside the range.
By their numbers in this assay, from the lowest: compounds 3 and 4 (each within the scatter of the next); then compound 2.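

In this assay the series now holds its first measured pair that differs only in configuration, and the step for a stereocentre at a saturated chain carbon, drawn S and then R, reads a number 0.10 log units higher from compound 3 to compound 4 (within the scatter). A step of this size does not separate the two configurations at this position, as it is comparable to the spread between repeated entries of a single compound: the several entries of compound 1 in this assay, 2.7; 2.8 (2 entries). Among these compounds, with no atom or bond entering or leaving, compound 3 and compound 4 can be read as one level in this assay, which the earlier compounds, differing from one another in more than one place, could not show: the fact that compounds 3 and 4 differ only in the configuration as drawn.

As far as these compounds go, this rests on a single pair at a single position, so it remains open whether the two configurations would also read alike with a carboxylic acid or a longer chain on this carbon in place of the hydroxyl. From the compounds shown here alone, it also remains open whether the configuration at this stereocentre would matter in any read-out other than this assay.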